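Trifluoromethyl to Fluoro on the Hydrazone Aryl Ring

The source may hold more compounds than are shown below. What is called first, only, known or untested is meant among the compounds shown, and "the series" means these compounds.

Measured compounds:
Compound 1 `COc1cc(C2=NN(C(C)=O)C(c3ccc(F)c(F)c3)O2)cc(OC)c1OC` gives 35.5% in a functional assay on PC-3 cells (Homo sapiens) for antiproliferative activity, read by MTT assay, tested at 1 uM; a lower number here means a weaker effect, a higher number a stronger effect of the compound at the concentration tested.
Compound 2 `COc1cc(C(=O)N/N=C/c2ccc(C(F)(F)F)cc2)cc(OC)c1OC` gives 59.9% in this assay.
Compound 3 `COc1cc(/C=N/NC(=O)c2cc(OC)c(OC)c(OC)c2)cc(OC)c1OC` gives 8.5% in this assay.

Among the three compounds measured in this assay, compound 2 stands highest. Compound 1 is its nearest neighbour, with a number that lies lower by a margin beyond the scatter, and compound 3 is furthest, lower still by a margin well beyond the scatter. Compound 2 and compound 3 share the shared core on the acyl side and differ in the aryl ring on the other side of the hydrazone; their two values show how strongly that ring can shift the read-out.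

Compound 4 `COc1cc(C(=O)N/N=C/c2ccc(F)cc2)cc(OC)c1OC` is not yet measured. It differs from compound 2 in one place: fluoro in place of trifluoromethyl on an aromatic carbon. The remaining part of the structure is unchanged.

Among the compounds with values here, no measured pair gives a direct step of this kind, so the expectation rests on compound 2 alone. A step downward in this assay that is modest and near the edge of the scatter is expected, a number 13.9 percentage points lower from compound 2 to compound 4 (beyond the scatter). Compound 4 is therefore estimated at 46%, within a range from 26% to 64%.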

Compound 4, a percentage reported as inhibition, at one concentration (the size of the read-out at that concentration, not a potency): 76%
Estimate against measurement, compound 4: 30 percentage points below, outside the stated range (above it).
By their numbers in this assay, from the lowest: compound 3; then compound 1; then compound 2; then compound 4.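

In this assay, this position now has its first direct step, and it runs upward, with fluoro in place of trifluoromethyl on an aromatic carbon giving a number 16.1 percentage points higher from compound 2 to compound 4 (beyond the scatter) while the remaining structure stays unchanged. The change at this carbon, para to a large group, thus shows that trifluoromethyl is not required there for the read-out, and that the smaller fluoro group is at least as well accepted at this one concentration, with a margin that lies beyond the scatter. Nothing available bears on why the exchange raises the number, so the result stands as an observation about these two structures alone.

As far as these compounds go, what remains open is whether this gain belongs to fluoro in particular or extends to other groups at the same carbon, such as chloro, bromo, a nitrile, an amine or a carboxylic acid. From the compounds shown here alone, it is also open whether the same exchange would move the read-out in the same direction if the shared core were altered, since this single pair cannot establish a trend and a reading at one concentration is not a potency.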